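This account rests on a few compounds, and the source may have more. Where it says the series, first, only, none or still open, it means among the compounds named here.

Two measured compounds share one core and differ only in the aromatic group on a carbon with a double bond to nitrogen. Compound 1 `COc1ccc(/C=N/NC(=S)NC(C)(C)[C@H]2CC=C(C)CC2)cc1` carries a 4-methoxyphenyl group there, and in a functional assay on NCI/ADR-RES cells (Homo sapiens) for inhibition, read by sulforhodamine B assay, with a stated time of 48 h (on this read-out higher numbers stand for weaker inhibition of growth and lower numbers for stronger inhibition of growth), compound 1 gives 43800 nM. Compound 2 `CC1=CC[C@H](C(C)(C)NC(=S)N/N=C/c2cccc(Cl)c2)CC1` carries a 3-chlorophenyl group instead, and in this assay compound 2 gives 67500 nM. Among the compounds with values here, of the two numbers recorded, the one for compound 2 is the larger, but the step of a 1.5-fold higher number from compound 1 to compound 2 (0.19 log units; within the scatter) is within the scatter, so the two compounds cannot be told apart on this read-out.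

Compound 3 `CC1=CC[C@H](C(C)(C)NC(=S)N/N=C/c2cccs2)CC1` has not yet been measured. It arises from compound 2 by a change in the same place: thiophen-2-yl in place of 3-chlorophenyl on a carbon with a double bond to nitrogen. Within the data shown here, the only measured step that bears on this change is the one from compound 1 to compound 2, which also swaps the aromatic group on that carbon, and that step stayed within the scatter. For compound 3 the expected step is therefore no change at the digits printed from compound 2 to compound 3 (within the scatter), meaning no change beyond the scatter. Compound 3 is estimated to give 67500 nM in this assay, within a range from 25000 nM to 180000 nM.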

Compound 3, concentration for 50% growth inhibition: 13600 nM
The estimate for compound 3 lay 5.0-fold (0.70 log units) above the measured number; the whole stated range lies above it.
By their numbers in this assay, from the lowest: compound 3; then compounds 1 and 2 (each within the scatter of the next).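

In this assay, the aromatic group on a carbon with a double bond to nitrogen turns out to matter. The earlier swap between two substituted phenyl groups gave no readable change, yet thiophen-2-yl gives a 5.0-fold lower number from compound 2 to compound 3 (0.70 log units; beyond the scatter) and also a 3.2-fold lower number from compound 1 to compound 3 (0.51 log units; beyond the scatter). This position is therefore not indifferent to the group it carries, and compound 3, whose steps to both other compounds lie beyond the scatter, is the strongest growth inhibitor of the three, though by a modest margin.

This change replaces a six-membered aromatic ring of carbon only with a five-membered aromatic ring holding one sulfur atom, so ring size and the hetero atom change together, and a furan-2-yl group or an unsubstituted phenyl group would be needed to begin separating the two. The data shown offer no measurement that explains why the number falls with thiophen-2-yl.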